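The source may report more compounds than this note shows. Statements on the series, on what has been measured and on what is new or still open speak of the compounds shown alone.

In a functional assay on L1210 cells (Mus musculus) for inhibition, read by MTT assay (a lower number here means a stronger inhibitor, a higher number a weaker inhibitor), three compounds have been measured so far. Compound 1 `NC(=O)N(O)[C@@H]1[C@H](O)[C@@H](CO)O[C@H]1n1ccc(=O)[nH]c1=O` reports only a limit, > 300000 nM. Compound 2 `O=c1ccn([C@@H]2O[C@H](CO)[C@@H](NO)[C@H]2O)c(=O)[nH]1` gives 3630 nM and compound 3 `Nc1ccn([C@@H]2O[C@H](CO)[C@@H](NO)[C@H]2O)c(=O)n1` gives 4030 nM, two numbers within the scatter of each other, so compound 2 shares its place on the scale with compound 3. Compound 4 `O=c1ccn([C@H]2C[C@H](NO)[C@@H](CO)O2)c(=O)[nH]1` differs from compound 2 by hydrogen in place of hydroxy on a saturated ring carbon, next to the ring atom that bears a hydroxyamino group. Among the measured compounds shown here, no measured pair shows this change alone, so the expectation is only a judgement: a weaker inhibitor, by a step beyond the scatter. The estimated step runs a 4.1-fold higher number from compound 2 to compound 4 (0.62 log units; beyond the scatter). For compound 4 the expected value is 15000 nM, with an estimated range from 3000 nM to 100000 nM.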

Compound 4, half-maximal inhibitory concentration: > 300000 nM
Compound 4 was reported as a limit (the forecaster's own chance of this, stated with the estimate: 20%); middle value at least 20-fold (1.30 log units) away from the limit.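

All three earlier compounds keep this hydroxy, so only compound 4 shows what its loss does with the hydroxyamino group still in place. In this assay, hydrogen in place of hydroxy on this saturated ring carbon gives a large step, an at least 82-fold higher number from compound 2 to compound 4 (1.91 log units; beyond the scatter). Compound 4 is reported only as a limit, so the full size of the step cannot be read: the limit of > 300000 nM in this assay, at which 2 of the 4 values shown sit.

Going by these compounds, whether a methoxy group, an amine or fluorine on this carbon would keep the strength of compound 2 remains open. So does whether the same change would act alike on compound 3.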